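A few compounds are considered here, and "the series" means these few. Any claim that something is new, unique, unknown or untested is made for them only; others in the source may bear on it.

Measured compounds:
- Compound 1, `C[C@@H]1CCN(c2cc(-c3ccccc3)nc3ncnn23)C[C@@H]1N(C)c1ncnc2[nH]ccc12`, a limit in a functional assay on HGC-27 cells (Homo sapiens) for inhibition, read by MTT assay, with a stated time of 72 h; a lower number here means a stronger inhibitor, a higher number a weaker inhibitor: > 100000 nM
- Compound 2, `Cc1cc(N2CC[C@@H](C)[C@@H](N(C)c3ncnc4[nH]ccc34)C2)n2nc(SCc3ccc(Cl)cc3)nc2n1`: 18400 nM
- Compound 3, `Cc1cc(N2CC[C@@H](C)[C@@H](N(C)c3ncnc4[nH]ccc34)C2)n2nc(SCCc3ccccc3)nc2n1`: 11800 nM

The value given for compound 1 is a limit of the assay, not a number, as the limit of > 100000 nM in this assay, at which 1 of the 3 values shown sits, records. Among the two numbers, compound 2 stands highest, with compound 3 as its nearest neighbour; the only step between measured compounds, a 1.6-fold lower number from compound 2 to compound 3 (0.19 log units; within the scatter), is within the scatter and concerns a different part of the molecule, benzyl in place of 4-chlorophenyl on a saturated chain carbon bound to a sulfur.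

Compound 4, `COc1ccc(CSc2nc3nc(C)cc(N4CC[C@@H](C)[C@@H](N(C)c5ncnc6[nH]ccc56)C4)n3n2)cc1`, is not yet measured. It differs from compound 2 by methoxy in place of chloro on an aromatic carbon. Among the compounds with values here, no measured step touches this change, and the one step that alters the same side chain gave no movement beyond the scatter. For this assay, therefore, no step beyond the scatter is expected from compound 2 to compound 4, in either direction. The number for compound 4 is estimated at 15000 nM, with a range from 6000 nM to 40000 nM. This estimate means a step of a 1.2-fold lower number from compound 2 to compound 4 (0.09 log units; within the scatter), which is expected to stay within the scatter.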

Compound 4, half-maximal inhibitory concentration: 18200 nM
Estimate against measurement, compound 4: 1.2-fold (0.08 log units) below, and the stated range covers the measured number.
By their numbers in this assay, from the lowest: compounds 3, 4 and 2 (each within the scatter of the next). At a limit, above all of these: compound 1.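

Within the data shown here, compound 2 and compound 4 provide a direct test of the aromatic carbon para to a large group, a position that no earlier step had changed. In this assay, methoxy in place of chloro gives a 1.0-fold lower number from compound 2 to compound 4 (0.00 log units; within the scatter), so this exchange of a single chlorine for a group of two heavy atoms, one of them a hydrogen-bond acceptor, leaves no readable mark on the number. The other new comparison gives a 1.5-fold higher number from compound 3 to compound 4 (0.19 log units; within the scatter), which means that the side chains of compound 2, compound 3 and compound 4 cannot be told apart in this assay, and nothing measured here offers an explanation for this flat result.

Among these compounds, it remains open whether an amine or a carboxylic acid on this same aromatic carbon would produce a step beyond the scatter, since chloro and methoxy are the only two groups compared there. Also unresolved is how an unsubstituted benzyl group on the sulfur, or a longer chain between the sulfur and the aromatic ring, would read in this assay.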